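From Methyl to Methoxy on One Aromatic Carbon

The source may report more compounds than this note shows. Statements on the series, on what has been measured and on what is new or still open speak of the compounds shown alone.

Going by these compounds, three related compounds have been measured so far, and a fourth is still open. In an ADME assay on J774.A1 cells (Mus musculus) for inhibition, read by MTT assay, with a stated time of 72 h (on this read-out lower numbers stand for an effect already at smaller amounts and higher numbers for an effect only at larger amounts of compound), compound 3 (`Cc1ccc(CNc2nc(NCc3ccccc3)c3ccccc3n2)cc1`) gives 4500 nM as its half-maximal concentration. Compound 2 (`COc1ccc(CNc2nc(NCc3ccccc3)nc3ccccc23)cc1`) gives 5200 nM in the same test, so the two numbers lie within the usual scatter of each other. Compound 1 (`CC(C)Nc1nc(NCc2ccco2)c2ccccc2n1`) gives 17000 nM and stands apart, since its number is higher than that of compound 3 by more than the scatter.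

Compound 4 (`COc1ccc(CNc2nc(NCc3ccccc3)c3ccccc3n2)cc1`) differs from compound 3 in one place, where methoxy stands in place of methyl on an aromatic carbon (methoxy in place of methyl on an aromatic carbon). The 4-methylbenzyl group thus becomes a 4-methoxybenzyl group, and the rest of the structure stays the same. Going by the values given here, no measured pair shows this change directly, so the expectation is modest: no shift beyond the scatter. The expected step of a 1.1-fold higher number from compound 3 to compound 4 (0.03 log units; within the scatter) is correspondingly small. For compound 4 the estimated value is 4800 nM in this assay with an expected range from 2400 nM to 9600 nM when it is measured.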

Compound 4, half-maximal effective concentration: 4100 nM
For compound 4 the middle estimate is 1.2-fold (0.07 log units) above the measured one; the measured number falls inside the stated range.
By their numbers in this assay, from the lowest: compounds 4, 3 and 2 (each within the scatter of the next); then compound 1.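

Going by these compounds alone, the pair gives a 1.1-fold lower number from compound 3 to compound 4 (0.04 log units; within the scatter) in this assay when 4-methylbenzyl becomes 4-methoxybenzyl, and it is the first direct look at this change. At this place on the aromatic ring, methoxy adds one heavy atom and one hydrogen-bond acceptor, yet its number cannot be told apart from that of methyl, so neither group can be ranked above the other. No outside evidence bears on why these numbers agree.

Two groups at one position say little about the range of groups this place might accept: an amine, a hydroxyl or a chlorine could give a similar number or a clearly different one. Going by these compounds, it also remains open whether the same change would give a similar result on the unsubstituted benzyl group of the shared core.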